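The compounds below may be only part of what the source reports. "The series", "measured", "known", "first", "only" and "open" are said of these compounds alone.

Measured compounds:
Compound 1, `Cc1cnc(Nc2ccc(C#N)cc2)nc1Nc1c(F)cc(-c2cc(F)nc(F)c2)cc1F`, gives 103000 nM in a toxicity assay on MT4 cells (Homo sapiens) for cytotoxicity, read by MTT assay, with a stated time of 5 days; a lower number here means that less compound is tolerated, a higher number that more compound is tolerated.
Compound 2, `Cc1cnc(Nc2ccc(C#N)cc2)nc1Nc1c(F)cc(-c2ccc(C#N)nc2)cc1F`, gives 62000 nM in this assay.
Compound 3, `Cc1cc(-c2cncnc2)cc(C)c1Nc1ccnc(Nc2ccc(C#N)cc2)n1`, gives 6800 nM in this assay.

Compound 3 stands lowest of the three in this assay, and its gap to compound 2, as to compound 1, lies beyond the usual scatter of the measurement; so compound 3 is the one of these three that the cells tolerate least. Compound 4, `Cc1cc(-c2cc(C)c(Nc3ccnc(Nc4ccc(C#N)cc4)n3)c(C)c2)cc(C)n1`, shares the core of compound 3 and differs from it in one place: 2,6-dimethylpyridin-4-yl in place of pyrimidin-5-yl on an aromatic carbon. For the measured compounds named here, only one measured step is available, and it concerns a change at the same kind of place, the ring that hangs off the outer aromatic ring: a 1.7-fold lower number from compound 1 to compound 2 (0.22 log units; within the scatter). That swap of one heteroaromatic ring for another left the number where it was, within the scatter. The change from compound 3 to compound 4 is also a swap of one six-membered heteroaromatic ring for another at that position, so the nearest evidence points to no step beyond the scatter in this assay. The expected step is a 1.1-fold lower number from compound 3 to compound 4 (0.05 log units; within the scatter). Compound 4 is therefore estimated at 6000 nM, with a range from 2000 nM to 20000 nM.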

Compound 4, half-maximal cytotoxic concentration: 2300 nM
Compound 4: middle estimate off by 2.6-fold (0.42 log units), on the high side; the measured number falls inside the stated range.
By their numbers in this assay, from the lowest: compound 4; then compound 3; then compounds 2 and 1 (each within the scatter of the next).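

In this assay, the swap at this position, on an aromatic carbon para to a large group, gives a 3.0-fold lower number from compound 3 to compound 4 (0.47 log units; beyond the scatter), whereas the earlier swap gave a 1.7-fold lower number from compound 1 to compound 2 (0.22 log units; within the scatter). So exchanging one six-membered aromatic ring for another here does not always leave the number within the scatter, and with 2,6-dimethylpyridin-4-yl the cells tolerate less of the compound than with pyrimidin-5-yl. The entering ring differs in more than one way, with 8 heavy atoms against 6 and 1 hydrogen-bond acceptor against 2, and no measurement shown here explains the step.

The compounds shown do not separate the contribution of the added methyl groups from that of the change in ring nitrogens, which a plain pyridin-4-yl ring at this place would help to tease apart. Going by these compounds, it also remains open how the number would respond to a group that is not an aromatic ring, such as a morpholine or a simple amine, and whether the same swap would have a similar effect on the core of compound 1.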